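A few compounds are considered here, and "the series" means these few. Any claim that something is new, unique, unknown or untested is made for them only; others in the source may bear on it.

Compound 1 `CN(C)CCN(CCN(C)C)c1cccc(C(=O)N2CCc3ccc(OS(N)(=O)=O)cc3C2)c1` stands lowest of the three compounds measured in an assay on HEK293 cells for inhibition of Steryl-sulfatase (Homo sapiens), tested at 1 uM; a higher number here means a stronger effect of the compound at the concentration tested, a lower number a weaker effect. In this assay compound 1 gives 17.1%. Compound 2 `CCN(Cc1cccnc1)c1ccc(C(=O)N2CCc3ccc(OS(N)(=O)=O)cc3C2)cc1` gives 85.2% in this assay, and compound 3 `CN(C)CCN(Cc1ccccc1)c1ccc(C(=O)N2CCc3ccc(OS(N)(=O)=O)cc3C2)cc1` gives 57.8%. Both stand above compound 1 by margins beyond the usual scatter, compound 3 being the nearest and compound 2 the furthest. Among the measured compounds shown here, no two of the measured compounds differ in only one place, so no single measured step is known; what the numbers show is that the two compounds with smaller amine groups on the outer ring give the higher inhibition.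

Compound 4 `CCN(Cc1ccccc1)c1cccc(C(=O)N2CCc3ccc(OS(N)(=O)=O)cc3C2)c1` has not yet been measured. It differs from compound 1 in one place: benzyl(ethyl)amino in place of bis(2-(dimethylamino)ethyl)amino on an aromatic carbon. For the measured compounds named here, the groups that enter resemble parts of compound 2, which gives 85.2%, and of compound 3, which gives 57.8%, though compound 4 keeps the point of attachment of compound 1, meta to a large group, and no measured compound tells how that attachment alone changes the outcome.

On these grounds the chemist expects an increase from compound 1 to compound 4 of a number 27.9 percentage points higher from compound 1 to compound 4 (beyond the scatter), beyond the scatter. Compound 4 is therefore estimated at 45%, in a range from 15% to 75%.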

Compound 4, a percentage reported as inhibition, at one concentration (the size of the read-out at that concentration, not a potency): 69%
Compound 4: middle estimate off by 24 percentage points, on the low side; measured number inside the range.
By their numbers in this assay, from the lowest: compound 1; then compound 3; then compound 4; then compound 2.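

In this assay, among the compounds shown here, benzyl(ethyl)amino in place of bis(2-(dimethylamino)ethyl)amino on an aromatic carbon, meta to a large group, gives the first single-place step: a number 51.9 percentage points higher from compound 1 to compound 4 (beyond the scatter), a large change. The step shows that this point of attachment does not by itself hold inhibition down, since with benzyl(ethyl)amino on that carbon compound 4 gives 69%, so the low number of compound 1 goes with the group it carries there. The two groups are close in size by their heavy-atom counts, so the step goes with what the group is made of and not with its heavy-atom count, though no measurement here explains it.

The compounds shown leave open which part of the exchange carries the step, the loss of the 2-(dimethylamino)ethyl chains or the gain of the benzyl ring, and a diethylamino group on the same carbon would separate the two. They also leave open how a ring amine such as morpholine would fare there, and whether benzyl(ethyl)amino gives a like number on another carbon of that ring.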